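Swapping the furan-2-yl of compound 3 for iodo

A few compounds are considered here, and "the series" means these few. Any claim that something is new, unique, unknown or untested is made for them only; others in the source may bear on it.

Compound 3, `CNc1ncnc2c1c(-c1ccco1)cn2[C@@H]1O[C@H](CO)[C@@H](O)[C@H]1O`, is the only one of the three measured compounds with an actual number in a functional assay on A549 cells (Homo sapiens), read by MTT assay, with a stated time of 72 h; a higher number here means a weaker inhibitor, a lower number a stronger inhibitor: compound 3 gives 2570 nM. Compound 1, `CNc1ncnc2c1c(-c1ccccc1)cn2[C@@H]1O[C@H](CO)[C@@H](O)[C@H]1O`, sits at the assay limit with > 20000 nM. Compound 2, `CNc1ncnc2c1c(-c1ccoc1)cn2[C@@H]1O[C@H](CO)[C@@H](O)[C@H]1O`, also sits at the limit with > 20000 nM. Compound 4, `CNc1ncnc2c1c(I)cn2[C@@H]1O[C@H](CO)[C@@H](O)[C@H]1O`, differs from compound 3 in one place: iodo in place of furan-2-yl on an aromatic carbon. Among the compounds with values here, no measured step removes the aromatic group entirely, so the change has no direct precedent. The steps of an at least 7.7-fold lower number from compound 1 to compound 3 (0.89 log units; beyond the scatter) and an at least 7.7-fold lower number from compound 2 to compound 3 (0.89 log units; beyond the scatter) show that the group on that carbon decides whether a number is read at all, and only furan-2-yl gave one. Taking it away is therefore expected to weaken compound 4, by an estimated 3.1-fold higher number from compound 3 to compound 4 (0.49 log units; beyond the scatter), to about 8000 nM in this assay, with a range of 1500 nM to 20000 nM.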

Compound 4, half-maximal inhibitory concentration: > 100000 nM
Compound 4 ended at the assay's limit; the forecaster's own chance of this, stated with the estimate: 40%; at least 12-fold (1.09 log units) between middle value and limit.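

In this assay, within the data shown here, putting iodo in place of furan-2-yl gives an at least 38-fold higher number from compound 3 to compound 4 (1.59 log units; beyond the scatter), the only readable step at this position that leaves no ring on the aromatic carbon. Among the four groups shown on this carbon, furan-2-yl remains the only one that gives a number, so a small non-ring group does not restore a reading. Compound 4 gives a limit, not a number: the limit of > 100000 nM in this assay, at which 1 of the 4 values shown sits.

The steps from compound 1 and compound 2 to compound 4 join two limits and cannot be read. As far as these compounds go, whether thiophen-2-yl or an amine on this carbon would give a number stays open.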